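Halogen exchange on the aryl ketone of compound 1

The compounds below may be only part of what the source reports. "The series", "measured", "known", "first", "only" and "open" are said of these compounds alone.

Compound 1 `COc1cc(-c2cc(/C=C/C(=O)c3ccc(Cl)c(Cl)c3)[nH]n2)cc(OC)c1OC` stands highest of the three numbers in a functional assay on SN12C cells (Homo sapiens) for cytotoxicity, read by sulforhodamine B assay, with a stated time of 48 h, tested at 1 uM (a higher number here means a weaker effect of the compound at the concentration tested, a lower number a stronger effect), where compound 1 gives 91%. Compound 2 `COc1ccc(-c2cc(/C=C/C(=O)c3cc(OC)c(OC)c(OC)c3)[nH]n2)cc1OC` gives 87%, within the scatter of compound 1, while compound 3 `COc1cc(C(=O)/C=C/c2cc(-c3cc(OC)c(OC)c(OC)c3)n[nH]2)cc(OC)c1OC` gives 78%, beyond it. Within the data shown here, the only measured step, a number 9 percentage points lower from compound 2 to compound 3 (within the scatter), concerns a methoxy in place of hydrogen on an aromatic carbon and does not touch the present change. Among the measured compounds shown here, compound 4 `COc1cc(-c2cc(/C=C/C(=O)c3ccc(F)c(F)c3)[nH]n2)cc(OC)c1OC` differs from compound 1 by 3,4-difluorophenyl in place of 3,4-dichlorophenyl on a carbonyl carbon; no measured pair bears on this exchange. For the measured compounds named here, with no step to set a direction, the step of a number 1 percentage points lower from compound 1 to compound 4 (within the scatter) is expected to remain within the scatter. Compound 4 is therefore estimated at 90%, in the range 80% to 100%.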

Compound 4, a percentage reported as activity, at one concentration (the size of the read-out at that concentration, not a potency): 89%
Estimate against measurement, compound 4: 1 percentage points above, within the range that was stated.
By their numbers in this assay, from the lowest: compounds 3, 2, 4 and 1 (each within the scatter of the next, the first and the last beyond it).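

In this assay, among these compounds, the exchange on the carbonyl carbon gives the only step at this position, a number 2 percentage points lower from compound 1 to compound 4 (within the scatter), so this pair of halogens on the aryl ketone does not separate the two compounds at the concentration tested. Nothing at hand bears on why the read-out stays within the scatter. Still open, going by these compounds, is whether an aminophenyl, a carboxyphenyl or an unsubstituted phenyl on the carbonyl carbon would give a step beyond the scatter. A single pair also leaves open whether the same exchange behaves alike on another aryl group on the shared core.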